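Adding an Amino Link: Expected Effect on Growth Inhibition

The compounds below may be only part of what the source reports. "The series", "measured", "known", "first", "only" and "open" are said of these compounds alone.

Compound 1, `COc1cc(-c2nn(-c3cccc(NC(=O)Nc4cc(C(F)(F)F)cc(C(F)(F)F)c4)c3)cc2-c2ccncc2)ccc1Cl`, gives 950 nM in a functional assay on 786-0 cells (Homo sapiens) for inhibition, read by sulforhodamine B assay, with a stated time of 48 h; a higher number here means a weaker inhibitor of growth, a lower number a stronger inhibitor of growth.
Compound 2, `COc1cc(-c2nn(-c3cccc(NC(=O)c4cccc(C(F)(F)F)c4)c3)cc2-c2ccncc2)ccc1Cl`, gives 2450 nM in this assay.

Going by the values given here, of these two, compound 2 has the higher number, so it is the weaker growth inhibitor; its only neighbour, compound 1, lies lower by a margin beyond the usual scatter. Compound 3, `COc1cc(-c2nn(-c3cccc(NC(=O)Nc4cccc(C(F)(F)F)c4)c3)cc2-c2ccncc2)ccc1Cl`, is not yet measured. It differs from compound 2 in one place: (3-(trifluoromethyl)phenyl)amino in place of 3-(trifluoromethyl)phenyl on a carbonyl carbon. Among the compounds with values here, a carbonyl carrying an amino-linked ring is also present in compound 1, which in this assay gives 950 nM, and that is the only guide here. The step from compound 2 to compound 3 is therefore expected to be downward, a 1.9-fold lower number from compound 2 to compound 3 (0.28 log units; within the scatter), though compound 1 also carries a second trifluoromethyl group, so the two cases are not identical. For compound 3 the expected value is 1300 nM, within a range of 450 nM to 3800 nM.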

Compound 3, concentration for 50% growth inhibition: 1280 nM
Compound 3: the middle estimate sits 1.0-fold (0.01 log units) above what was measured; measured number inside the range.
By their numbers in this assay, from the lowest: compounds 1, 3 and 2 (each within the scatter of the next, the first and the last beyond it).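

Compound 3 separates two changes that were mixed together before, since compounds 1 and 2 differ in both the amino link and a second trifluoromethyl group. In this assay the amino link alone gives a 1.9-fold lower number from compound 2 to compound 3 (0.28 log units; within the scatter) and removing the second trifluoromethyl group alone gives a 1.3-fold higher number from compound 1 to compound 3 (0.13 log units; within the scatter) so neither change, taken by itself, can be told apart from the ordinary variation between repeated measurements. Nothing measured here offers an explanation for these numbers.

The compounds shown leave open whether another link on the carbonyl carbon, such as the oxygen of a carbamate or a methylene group, would match the amino link. They also leave open what a nitrile or a fluorine would give in place of the trifluoromethyl group on the aromatic ring.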